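This account rests on a few compounds, and the source may have more. Where it says the series, first, only, none or still open, it means among the compounds named here.

Compound 1 `COc1ccc(OC)c(C2=C(c3cc(OC)c(OC)c(OC)c3)C(=O)CC2O[SiH2]C(C)(C)C)c1`: 17 ug/mL
Compound 2 `COc1ccc(OC)c(C2=C(c3cc(OC)c(OC)c(OC)c3)C(=O)CC2O)c1`: > 100 ug/mL (a limit of the assay)

Going by the values given here, in an ADME assay on PA-1 cells (Homo sapiens) for cytotoxicity, read by MTT assay, with a stated time of 72 h (on this read-out lower numbers stand for stronger inhibition and higher numbers for weaker inhibition), compound 1 holds the only actual number, 17 ug/mL. Compound 2 gives only a limit, > 100 ug/mL.

Among the compounds with values here, the one measured step, an at least 5.8-fold higher number from compound 1 to compound 2 (0.76 log units; beyond the scatter), puts a hydrogen atom in place of the silicon-bearing group on the oxygen on a saturated carbon. Compound 3 `COCOc1cc(C2=C(c3cc(OC)c(OC)c(OC)c3)C(=O)CC2O[SiH2]C(C)(C)C)ccc1OC` keeps that group, and its change lies elsewhere: 4-methoxy-3-(methoxymethoxy)phenyl in place of 2,5-dimethoxyphenyl on a double-bonded ring carbon. Here, 4-methoxy-3-(methoxymethoxy)phenyl stands in place of 2,5-dimethoxyphenyl on a double-bonded ring carbon.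

Within the data shown here, the measured step therefore bears on this change only indirectly, and no measured step covers this place. With nothing to suggest a direction, the reasonable starting point is compound 1 at 17 ug/mL, with wide uncertainty around it. The expected change is small, a 1.2-fold higher number from compound 1 to compound 3 (0.07 log units; within the scatter), which would stay within the usual scatter. In this assay, compound 3 is estimated at 20 ug/mL, with an expected range of 7 ug/mL to 60 ug/mL.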

Compound 3, half-maximal inhibitory concentration: 13.5 ug/mL
Estimate against measurement, compound 3: 1.5-fold (0.17 log units) above; the measured number falls inside the stated range.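

The exchange of 2,5-dimethoxyphenyl for 4-methoxy-3-(methoxymethoxy)phenyl on a double-bonded ring carbon gives a 1.3-fold lower number from compound 1 to compound 3 (0.10 log units; within the scatter), so this assay does not tell these two compounds apart. Going by these compounds alone, this is the first measured change at this position, and it shows that a different aryl group, with more heavy atoms and one more hydrogen-bond acceptor, can sit there while the assay still returns an actual number. Compound 1 and compound 3 both keep the silicon-bearing group on the oxygen, and the two aryl groups shown here do not separate them.

As far as these compounds go, compound 2 gives only a limit, so the full size of the step on removing the silicon-bearing group stays unknown, and whether that step would look the same with 4-methoxy-3-(methoxymethoxy)phenyl in place stays open as well: the limit of > 100 ug/mL in this assay, at which 1 of the 3 values shown sits. Also open is whether a phenyl ring carrying an amine or a carboxylic acid, rather than the oxygen-linked groups on these two rings, would give a similar number at this position.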